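The source may hold more compounds than are shown below. What is called first, only, known or untested is meant among the compounds shown, and "the series" means these compounds.

Of the compounds shown here, three sharing one core have been measured in a physicochemical assay for lipophilicity, using the shake flask method, at pH 7.4; a lower number here means a more polar compound, a higher number a more lipophilic compound. Compound 1 `CCCC(Oc1ccc(-n2cc(C(=O)N(C)C)cn2)cc1)c1ccc(C(=O)NCCC(=O)O)cc1` gives 0.5, compound 2 `CCCC(Oc1ccc(-n2cc(C(F)(F)F)c(C)n2)cc1)c1ccc(C(=O)NCCC(=O)O)cc1` gives 2.8, and compound 3 `CCCC(Oc1ccc(-n2cc3c(n2)CCCC3)cc1)c1ccc(C(=O)NCCC(=O)O)cc1` gives 2.7. Compound 3 cannot be told apart from its nearest neighbour, the gap being a number 0.10 log units lower from compound 2 to compound 3 (within the scatter). Its furthest neighbour lies well away, the gap being a number 2.20 log units higher from compound 1 to compound 3 (beyond the scatter).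

Compound 4 `CCCC(Oc1ccc(-n2cc(F)cn2)cc1)c1ccc(C(=O)NCCC(=O)O)cc1` has not yet been measured. It departs from compound 3 at one place, on an aromatic carbon of a six-membered aromatic ring of carbon only: a group of 6 heavy atoms (3 carbon, 2 nitrogen, 1 fluorine; one five-membered aromatic ring with 2 hetero atoms) in place of a group of 9 heavy atoms (7 carbon, 2 nitrogen; one five-membered aromatic ring with 2 hetero atoms, one six-membered non-aromatic ring of carbon only), on an aromatic carbon. The incoming 4-fluoro-1H-pyrazol-1-yl group has no six-membered non-aromatic ring and is the smaller of the two.

Among the measured compounds shown here, no measured step makes this exact swap, but all three changed the same place. Two were large, a number 2.30 log units higher from compound 1 to compound 2 (beyond the scatter) and a number 2.20 log units higher from compound 1 to compound 3 (beyond the scatter), so the group here can matter a great deal in this assay. Both start from the dimethylcarbamoyl group of compound 1, which compound 4 lacks, so a drop of that size seems unlikely. The third step, a number 0.10 log units lower from compound 2 to compound 3 (within the scatter), shows that one group can replace another with no visible change, but those two groups are closer in size. A moderate fall is therefore the best guess. For compound 4 the expected step is a number 0.60 log units lower from compound 3 to compound 4 (beyond the scatter). Compound 4 is estimated at 2.1, with an expected range from 1.7 to 2.5.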

Compound 4, distribution coefficient: 2
For compound 4 the middle estimate is 0.10 log units above the measured one, and the stated range covers the measured number.
By their numbers in this assay, from the lowest: compound 1; then compound 4; then compounds 3 and 2 (each within the scatter of the next).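

In this assay, among the compounds shown here, the 4-fluoro-1H-pyrazol-1-yl group gives this position a middle level of its own, with a number 0.70 log units lower from compound 3 to compound 4 (beyond the scatter) and a number 0.80 log units lower from compound 2 to compound 4 (beyond the scatter), where the earlier compounds showed only a low level and a high one. This middle level also stands clear of the low end, with a number 1.50 log units higher from compound 1 to compound 4 (beyond the scatter) showing that fluoro in place of dimethylcarbamoyl already covers much of the distance seen with the two larger groups. Group size alone does not set the order among these four compounds: compound 4 carries the smallest group, yet it sits above compound 1, whose larger group gives the lowest number of all.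

The compounds shown leave open where other small groups would fall, for example whether a nitrile, a hydroxyl or an amine in place of the fluoro of compound 4 would stay at this middle level or move towards compound 1. Nothing here gives a measured reason for any of these steps, so the gaps stand as observations only.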